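A few compounds are considered here, and "the series" means these few. Any claim that something is new, unique, unknown or untested is made for them only; others in the source may bear on it.

Measured so far in a functional assay on NCI-H460 cells (Homo sapiens) for cytotoxicity, read by MTT assay, with a stated time of 72 h; on this read-out lower numbers stand for stronger inhibition and higher numbers for weaker inhibition:

compound 1, `CN(C)CCCNc1nc(-c2ccc(NC(=O)Nc3ccccc3Cl)cc2)nc2ccsc12`: 430 nM
compound 2, `CN(C)CCCNc1nc(-c2ccc(NC(=O)Nc3ccc(Cl)cc3Cl)cc2)nc2ccsc12`: 1020 nM
compound 3, `CCN(CC)CCCNc1nc(-c2ccc(NC(=O)Nc3ccccc3)cc2)nc2c(Cl)c(Cl)sc12`: 850 nM

Compound 1 holds the lowest of the three numbers in this assay. The nearest is compound 3, whose value sits within the usual scatter of that of compound 1, so the two cannot be ordered. Among the compounds with values here, the one step that isolates a single change is a 2.4-fold higher number from compound 1 to compound 2 (0.38 log units; beyond the scatter), a modest shift beyond the scatter.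

Compound 4, `CCN(CC)CCNc1nc(-c2ccc(NC(=O)Nc3ccccc3Cl)cc2)nc2ccsc12`, is reached from compound 1 by one change: diethylamino in place of (dimethylamino)methyl on a saturated chain carbon, two bonds along the chain from a nitrogen on an aromatic ring. Within the data shown here, no measured pair isolates this change. Among the measured compounds shown here, compound 3 does carry a diethylamino group on its chain, but it also differs from compound 1 at two further places, so its number next to that of compound 1 shows only that the two values lie within the scatter of each other; nothing can be drawn from it about the chain alone. The step from compound 1 to compound 2 concerns a different part of the molecule and does not bear on this change.

With nothing to point either way, the expectation is for no step beyond the scatter, a 1.2-fold higher number from compound 1 to compound 4 (0.07 log units; within the scatter). Compound 4 is therefore estimated at 500 nM, with a range of 200 nM to 1300 nM given the absence of any direct precedent.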

Compound 4, half-maximal inhibitory concentration: 320 nM
For compound 4 the middle estimate is 1.6-fold (0.19 log units) above the measured one; low and high end bracket the measured number.
By their numbers in this assay, from the lowest: compounds 4, 1, 3 and 2 (each within the scatter of the next, the first and the last beyond it).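

In this assay the exchange of the 3-(dimethylamino)propyl chain for the 2-(diethylamino)ethyl chain now has a direct reading: a 1.3-fold lower number from compound 1 to compound 4 (0.13 log units; within the scatter) with the rest of the molecule unchanged. This position therefore accepts the exchange without a shift that can be told from the scatter, so no order can be set between these two compounds; compound 3 could not show this, as it carries its diethylamino group alongside differences at two further places. Nothing measured here gives a reason for this result.

As far as these compounds go, the exchange alters chain length and amine substituents together, so a 2-(dimethylamino)ethyl or a 3-(diethylamino)propyl chain would be needed to read each apart, and how this position responds to a cyclic amine such as pyrrolidine or morpholine, or to a longer chain, remains open. Also open, from the compounds shown here alone, is whether the exchange reads the same with the dichlorinated phenyl urea of compound 2 or the dichlorinated core of compound 3 in place of the groups shared by compound 1 and compound 4.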